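The source may report more compounds than this note shows. Statements on the series, on what has been measured and on what is new or still open speak of the compounds shown alone.

Of the compounds shown here, three have been measured in an ADME assay on microsomes from liver (Mus musculus) for metabolic stability, read by LC-MS, with a stated time of 30 min, tested at 1 ug/mL; a higher number here means that more of the compound is left, a lower number that less of the compound is left. Compound 1 (`COc1ccc(Oc2ccc(N3CC(=O)N([C@@H](CC4CCN(C(=O)C(C)C)CC4)c4nc5ccc(C)cc5n4C4CC4)C3=O)cc2)cc1`) gives 22.8% and compound 2 (`COc1ccc(Oc2ccc(N3CC(=O)N([C@@H](CC4CCN(C(=O)C(C)C)CC4)c4nc5ccc(F)cc5n4C)C3=O)cc2)cc1`) gives 24.1%, two values within the scatter of each other. Compound 3 (`Cc1ccc2nc([C@H](CC3CCN(C(=O)C(C)C)CC3)N3C(=O)CN(c4ccc(Oc5ccc(F)cc5)cc4)C3=O)n(C)c2c1`) gives 10.6%, the lowest of the three and beyond the scatter from both others.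

Compound 4 (`COc1ccc(Oc2ccc(N3CC(=O)N([C@@H](CC4CCN(C(=O)C(C)C)CC4)c4nc5ccc(C)cc5n4C)C3=O)cc2)cc1`) differs from compound 3 in one place: methoxy in place of fluoro on an aromatic carbon. It has methoxy in place of fluoro on an aromatic carbon, so 4-fluorophenoxy becomes 4-methoxyphenoxy. For the measured compounds named here, no measured pair isolates this change, so there is no direct evidence for its size. The nearest guide is that compound 1, at 22.8%, and compound 2, at 24.1%, both carry 4-methoxyphenoxy, although each also differs from compound 3 elsewhere. A rise in this assay is therefore expected, close to the edge of the scatter. The estimated change is a number 9.4 percentage points higher from compound 3 to compound 4 (within the scatter). For compound 4 the estimate is 20%, with an expected range of 10% to 32%.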

Compound 4, percent of the compound remaining: 2.4%
The estimate for compound 4 lay 17.6 percentage points above the measured number, outside the stated range (below it).
By their numbers in this assay, from the lowest: compounds 4 and 3 (each within the scatter of the next); then compounds 1 and 2 (each within the scatter of the next).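

In this assay, methoxy in place of fluoro, para to a large group, gives a number 8.2 percentage points lower from compound 3 to compound 4 (within the scatter), so this step offers no sign that 4-methoxyphenoxy alone accounts for the higher numbers of compound 1 and compound 2. With 4-methoxyphenoxy held constant, the steps beyond the scatter lie elsewhere in the shared core: replacing fluoro with methyl on the core gives a number 21.7 percentage points lower from compound 2 to compound 4 (beyond the scatter), and methyl in place of cyclopropyl on an aromatic nitrogen gives a number 20.4 percentage points lower from compound 1 to compound 4 (beyond the scatter). Nothing available explains any of these steps.

The compounds shown leave open whether the step from 4-fluorophenoxy to 4-methoxyphenoxy would look the same with fluoro or cyclopropyl at those two core positions. They also leave open how an amine or a carboxylic acid in place of the methoxy would read in this assay.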